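The source may report more compounds than this note shows. Statements on the series, on what has been measured and on what is new or still open speak of the compounds shown alone.

Of the compounds shown here, two have been tested in a functional assay on the whole organism for inhibition, with Rattus norvegicus as the target; on this read-out higher numbers stand for an effect only at larger amounts of compound and lower numbers for an effect already at smaller amounts. Compound 1 `CN(C)C(=O)n1cc(C(=O)c2ccn3c2CSC3c2cccnc2)c2ccc(Oc3ccc(F)cc3)cc21` gives 0.03 mg/kg in this assay. Compound 2 `Cn1cc(C(=O)c2ccn3c2CSC3c2cccnc2)c2ccc(-c3ccc(F)cc3)cc21` gives 0.09 mg/kg in this assay; of the two numbers it is the higher, and the gap to compound 1 lies beyond the usual scatter. Among the measured compounds shown here, the two differ in more than one place, so no single step between them is available, and only their two values can be read.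

The next compound, compound 3 `O=C(O)CCn1cc(C(=O)c2ccn3c2CSC3c2cccnc2)c2ccc(-c3ccc(F)cc3)cc21`, is reached from compound 2 by one change: carboxymethyl in place of hydrogen on a saturated chain carbon bound to an aromatic nitrogen. For the measured compounds named here, nothing measured in this set shows what such a change does in this assay; the only comparison on hand, between compound 1 and compound 2, mixes two changes at once. The expectation for the step of a 1.7-fold higher number from compound 2 to compound 3 (0.22 log units; within the scatter) is therefore a modest shift toward a larger dose, possibly none beyond the scatter, with the outcome uncertain in either direction. On that basis compound 3 is expected to give about 0.15 mg/kg in this assay, with a range from 0.04 mg/kg to 0.6 mg/kg.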

Compound 3, dose for half-maximal effect: 0.1 mg/kg
Estimate against measurement, compound 3: 1.5-fold (0.18 log units) above; the range from low to high includes it.
By their numbers in this assay, from the lowest: compound 1; then compounds 2 and 3 (each within the scatter of the next).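

In this assay, among the compounds shown here, the first single-place comparison is carboxymethyl in place of hydrogen on a saturated chain carbon bound to an aromatic nitrogen (a 1.1-fold higher number from compound 2 to compound 3 (0.05 log units; within the scatter)), which places compound 2 and compound 3 within the scatter of each other. This shows that, on this scaffold, the read-out tolerates methyl being exchanged for 2-carboxyethyl, a group that brings a hydrogen-bond donor and a hydrogen-bond acceptor, with no difference that can be told from the scatter. Nothing available here accounts for this result.

What the compounds shown leave open is whether a different group at this place, such as an amine, a primary amide, a methyl ester of the carboxylic acid or a longer chain, would also stay within the scatter of compound 2. For the compounds shown here, they also leave open whether 2-carboxyethyl would read the same alongside the other features of compound 1, since that compound differs from compound 2 in more than one place and offers no single step for comparison.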